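A Phenyl for a Furan on the Shared Core

This account rests on a few compounds, and the source may have more. Where it says the series, first, only, none or still open, it means among the compounds named here.

Compound 1 `Nc1nc(N)c2c(-c3ccoc3)cn([C@@H]3O[C@H](CO)[C@@H](O)[C@H]3O)c2n1` carries a furan-3-yl group on an aromatic carbon of a five-membered aromatic ring with 1 nitrogen, part of a fused or bridged system of two rings. In a functional assay on HL-60 cells (Homo sapiens) for antiproliferative activity, read by XTT assay, with a stated time of 72 h (on this read-out higher numbers stand for weaker inhibition and lower numbers for stronger inhibition), compound 1 gives > 20000 nM, which is a limit of the assay rather than a measured number. Two companions share the same sugar and the same fused core but differ elsewhere. Compound 2 `O=c1[nH]cnc2c1c(-c1cc3ccccc3o1)cn2[C@@H]1O[C@H](CO)[C@@H](O)[C@H]1O` gives > 20000 nM in this assay, again a limit. Compound 3 `CN(C)c1ncnc2c1c(-c1cc3ccccc3o1)cn2[C@@H]1O[C@H](CO)[C@@H](O)[C@H]1O` gives > 20000 nM in this assay, also a limit. Compound 1 therefore stands exactly where the others stand, and the whole picture is the limit of > 20000 nM in this assay, at which 3 of the 3 values shown sit. Among the compounds with values here, no measured compound reaches an inhibition that the assay can put a number on.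

Compound 4 `Nc1nc(N)c2c(-c3ccccc3)cn([C@@H]3O[C@H](CO)[C@@H](O)[C@H]3O)c2n1` is the next step. Its change from compound 1 is phenyl in place of furan-3-yl on an aromatic carbon. Within the data shown here, with every measured compound sitting at the limit, there is no measured step between compounds to lean on. The expectation is that compound 4 will likewise fail to show a measurable value, so the step that the limit leaves unreadable from compound 1 to compound 4 is expected to be none beyond the scatter. Compound 4 is accordingly estimated at 30000 nM, with a range from 8000 nM to 100000 nM.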

Compound 4, half-maximal inhibitory concentration: > 15000 nM
Compound 4: no number, only a limit; the forecaster's own chance of this, stated with the estimate: 80%; the middle value is on the limit's open side.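

Within the data shown here, compound 1 and compound 4 both give only limits in this assay, so swapping furan-3-yl for phenyl yields no step that can be read. The compounds shown leave open how strongly any of them actually inhibits, and whether a change on the shared core can bring a value that this assay can put a number on.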